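A few compounds are considered here, and "the series" means these few. Any claim that something is new, unique, unknown or untested is made for them only; others in the source may bear on it.

Compound 1 `COc1ccc(-c2nc3c(NCCCNC(=O)C4CCCC4)c(C(N)=S)cnc3[nH]2)cc1` gives 46 nM in an assay on isolated protein for inhibition of serine/threonine-protein kinase TBK1 (Homo sapiens), read by mobility shift assay; on this read-out higher numbers stand for weaker inhibition and lower numbers for stronger inhibition.
Compound 2 `COc1ccc(-c2nc3cc(-c4csc(C#N)c4)cnc3[nH]2)cc1` gives > 30000 nM in this assay, and this is a limit of the assay, not a number.

Among the compounds with values here, compound 2 therefore stands at the limit of > 30000 nM in this assay, at which 1 of the 2 values shown sits, while compound 1 is the one compound whose measurement returns a number. The two share only part of their structure, and no single-point step between them is shown, so their values can only be set side by side.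

Compound 3 `COc1ccc(-c2nc3cc(-c4csc(C(C)=O)c4)cnc3[nH]2)cc1` is the compound still to be measured. It differs from compound 2 in one place: acetyl in place of cyano on an aromatic carbon. With compound 2 sitting at the limit and no measured step of this kind in hand, the change is expected to move the value little, if at all, beyond the usual scatter; the expected step is an at least 1.2-fold lower number from compound 2 to compound 3 (0.07 log units; that floor lies within the scatter). Compound 3 is accordingly estimated at 25000 nM, in a range from 5000 nM to 150000 nM, and a further limit reading is thought likely.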

Compound 3, half-maximal inhibitory concentration: 650 nM
Beside the measured number, compound 3's estimate is 38-fold (1.59 log units) above it; measured number below the stated range.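

Changing 5-cyanothiophen-3-yl to 5-acetylthiophen-3-yl gives, in this assay, an at least 46-fold lower number from compound 2 to compound 3 (1.66 log units; beyond the scatter). This shows that the group on this aromatic carbon, next to the ring sulfur, can decide between a limit reading and a measured number, which compound 1 and compound 2, differing in more than one place, could not show. Going by these compounds, compound 2 gave only a limit and not a number, so the step is a floor and its full size stays unknown because of where that compound stands: the limit of > 30000 nM in this assay, at which 1 of the 3 values shown sits.

The compounds shown leave open whether a smaller or different group in this place, such as an aldehyde, a carboxylic acid or an amine, would read like the acetyl. Also open, on these data alone, is whether the acetyl would give a similar result on the core of compound 1.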